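The source may hold more compounds than are shown below. What is called first, only, known or untested is meant among the compounds shown, and "the series" means these compounds.

Working notes on the series. In a functional assay on BGC-823 cells (Homo sapiens) for antiproliferative activity, read by MTT assay, with a stated time of 48 h (a lower number here means a stronger inhibitor, a higher number a weaker inhibitor), compound 1 `Clc1ccc(CSc2nnc(-c3cnccn3)s2)cc1` gives 13400 nM, compound 2 `Fc1ccc(CSc2nnc(-c3cnccn3)s2)c(F)c1` gives 14500 nM and compound 3 `Clc1cccc(CSc2nnc(-c3cnccn3)n2-c2ccccc2)c1` gives 20300 nM. Compound 3 stands within the scatter of both other compounds, so the three values form a single level and support no ranking.

Compound 4 `Fc1cccc(F)c1CSc1nnc(-c2cnccn2)n1-c1ccccc1` is not yet measured. It differs from compound 3 at one place: 2,6-difluorophenyl in place of 3-chlorophenyl on a saturated chain carbon bound to a sulfur. Among the compounds with values here, no two measured compounds differ in only one place, so the series offers no direct precedent for this change.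

In this assay no step beyond the scatter is expected. That expectation rests on compound 2 at 14500 nM, which carries fluorine on its ring and lies within the scatter of compound 3 at 20300 nM. The estimated step is small: a 1.1-fold lower number from compound 3 to compound 4 (0.05 log units; within the scatter). Compound 4 is estimated at 18000 nM, with an expected range of 9000 nM to 36000 nM.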

Compound 4, half-maximal inhibitory concentration: > 50000 nM
Compound 4: a limit, no number; the forecaster's own chance of this, stated with the estimate: 5%; at least 2.7-fold (0.44 log units) between middle value and limit.
By their numbers in this assay, from the lowest: compounds 1, 2 and 3 (each within the scatter of the next). At a limit, above all of these: compound 4.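

In this assay, 2,6-difluorophenyl in place of 3-chlorophenyl on a saturated chain carbon bound to a sulfur gives an at least 2.4-fold higher number from compound 3 to compound 4 (0.39 log units; beyond the scatter). Within the data shown here, this is the only step that can be read, and it shows that the number responds to a change at this position, which the single level of the earlier compounds could not show. The value of compound 4 is a limit of the assay and not a number, so the step has no upper end: the limit of > 50000 nM in this assay, at which 1 of the 4 values shown sits.

Going by these compounds, with one change at this position, it stays open whether the step follows from the loss of the chlorine or from the entry of the two fluorines. A plain phenyl, or a benzyl carrying an amine, on the same saturated chain carbon would help to separate these readings.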